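The compounds below may be only part of what the source reports. "The series", "measured", "known", "first", "only" and "open" are said of these compounds alone.

Measured so far:

Compound 1, `COc1cc(NC(C)CCCNC(=O)/C=C/c2ccccc2)c2ncccc2c1`, in an ADME assay on L6 cells (Rattus norvegicus) for cytotoxicity, read by resazurin assay, with a stated time of 70 h; on this read-out higher numbers stand for weaker inhibition and lower numbers for stronger inhibition: 18500 nM
Compound 2, `COc1cc(NC(C)CCCNC(=O)/C=C/c2ccc(C(F)(F)F)cc2)c2ncccc2c1`: 160000 nM
Compound 3, `COc1cc(NC(C)CCCNC(=O)NNC(=O)/C=C/c2cccc(C(F)(F)F)c2)c2ncccc2c1`: 10600 nM

Compound 4 is `COc1cc(NC(C)CCCNC(=O)NNC(=O)/C=C/c2cc(C(F)(F)F)cc(C(F)(F)F)c2)c2ncccc2c1` and has not yet been measured in this assay. It differs from compound 3 by trifluoromethyl in place of hydrogen on an aromatic carbon. The same kind of change separates compound 1 from compound 2, namely (trifluoromethyl in place of hydrogen on an aromatic carbon), though the surroundings differ: in compound 2 the group is para to a large group, while in compound 4 it is meta to a large group and meta to a trifluoromethyl group. The difference between the cores of compound 1 and compound 3 is not broken down here. That earlier change gave an 8.6-fold higher number from compound 1 to compound 2 (0.94 log units; beyond the scatter). On that basis the step is expected to be a 2.8-fold higher number from compound 3 to compound 4 (0.45 log units; beyond the scatter), smaller than the earlier one. Compound 4 is therefore estimated at 30000 nM, with a range from 10000 nM to 100000 nM.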

Compound 4, half-maximal inhibitory concentration: > 170000 nM
Compound 4: a limit, no number; the forecaster's own chance of this, stated with the estimate: 15%; at least 5.6-fold (0.75 log units) between middle value and limit.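

In this assay, trifluoromethyl in place of hydrogen on an aromatic carbon gave an 8.6-fold higher number from compound 1 to compound 2 (0.94 log units; beyond the scatter) on one core and an at least 16-fold higher number from compound 3 to compound 4 (1.20 log units; beyond the scatter) on the other, so the direction carried over in these two pairs. Compound 4 stands at a limit of the assay, not at a number: the limit of > 170000 nM in this assay, at which 1 of the 4 values shown sits. The pairs therefore show a shared direction but no shared size: the same change on two cores in this assay, an 8.6-fold higher number (0.94 log units; beyond the scatter) from compound 1 to compound 2 and an at least 16-fold higher number (1.20 log units; beyond the scatter) from compound 3 to compound 4; the limit leaves it open whether they differ.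

The compounds shown leave open whether the same direction would hold with a chlorine or a nitrile entering in place of the trifluoromethyl. They also leave open whether it would survive an amine or a carboxylic acid on the same aromatic ring, or a longer chain in the linker.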